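A few compounds are considered here, and "the series" means these few. Any claim that something is new, unique, unknown or untested is made for them only; others in the source may bear on it.

Compound 1 `O=c1c(C2N=C(c3ccccc3)SS2)coc2cc(Cl)ccc12`, compound 2 `O=c1c(C(=S)Nc2ccccc2)coc2ccccc12` and compound 3 `O=c1c(C(=S)Nc2ccccc2)coc2ccc(F)cc12` are the measured members of the set. How the core of compound 1 differs from the core of compound 2 is not broken down here. In a functional assay on A549 cells (Homo sapiens) for inhibition, read by sulforhodamine B assay, with a stated time of 48 h, tested at 100 uM (a higher number here means more inhibition of growth at the concentration tested, a lower number less inhibition of growth), compound 1 gives 76%. In this assay compound 2 gives 79%, and compound 3 gives 70%; all three numbers lie within the scatter of one another.

Compound 3 differs from compound 2 by fluoro in place of hydrogen on an aromatic carbon, and that change gave a number 9 percentage points lower from compound 2 to compound 3 (within the scatter). Compound 4 `O=c1c(C2N=C(c3ccccc3)SS2)coc2cc(Cl)c(F)cc12`, not yet measured, differs from compound 1 by fluoro in place of hydrogen on an aromatic carbon. Within the data shown here, this is the same kind of change, not the same one: in compound 4 the entering fluoro stands ortho to a chloro group (1 heavy atom), which has no counterpart around the place in compound 3. A single earlier instance is thin ground for any expectation.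

Among the measured compounds shown here, for compound 4 a step of a number 5 percentage points lower from compound 1 to compound 4 (within the scatter) is expected, resting on the one earlier instance, a number 9 percentage points lower from compound 2 to compound 3 (within the scatter). Compound 4 is therefore estimated at 71% in this assay, with a range from 55% to 85%.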

Compound 4, percent growth inhibition at one concentration: 57%
Compound 4: middle estimate off by 14 percentage points, on the high side; the measured number falls inside the stated range.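

In this assay, fluoro in place of hydrogen on an aromatic carbon gives a number 19 percentage points lower from compound 1 to compound 4 (beyond the scatter), and this step does not differ measurably from the earlier one: the same change on two cores in this assay, a number 9 percentage points lower (within the scatter) from compound 2 to compound 3 and a number 19 percentage points lower (beyond the scatter) from compound 1 to compound 4, 10 percentage points apart, within the scatter of two such steps

Among these compounds, both steps run downward, but only the one on the core of compound 1 lies beyond the scatter, so the two pairs are compatible with a shared step without establishing one. They give no rule for other cores, and they cannot separate the difference between the cores from the chloro group that stands ortho to the entering fluoro in compound 4.

The compounds shown leave open how an amine or a methoxy group on the same aromatic carbon would compare with fluoro. Also open, on these data alone, is what the same fluoro change would give on the core of compound 1 with hydrogen in place of the chloro group.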